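Swapping 3-cyanophenyl for 4-(trifluoromethyl)phenyl on a weak amide

The compounds below may be only part of what the source reports. "The series", "measured", "known", "first", "only" and "open" are said of these compounds alone.

In a functional assay on MCF7 cells (Homo sapiens) for inhibition, read by MTT assay (on this read-out lower numbers stand for stronger inhibition of growth and higher numbers for weaker inhibition of growth), compound 1 (`COc1cc2oc(-c3cccc(NC(=O)c4ccc(Cl)cc4)c3)cc(=O)c2c(OC)c1OC`) gives 8780 nM and compound 2 (`COc1cc2oc(-c3cccc(NC(=O)c4cccc(C#N)c4)c3)cc(=O)c2c(OC)c1OC`) gives 41700 nM as the higher of the two numbers. Compound 2 therefore stands at the weak end of this short series. Compound 3 (`COc1cc2oc(-c3cccc(NC(=O)c4ccc(C(F)(F)F)cc4)c3)cc(=O)c2c(OC)c1OC`) keeps the shared core and carries 4-(trifluoromethyl)phenyl in place of 3-cyanophenyl on a carbonyl carbon. Within the data shown here, one measured step bears on this change: a 4.7-fold higher number from compound 1 to compound 2 (0.68 log units; beyond the scatter) came with 3-cyanophenyl in place of 4-chlorophenyl at that same carbonyl carbon. Among the measured compounds shown here, compound 3 removes the 3-cyanophenyl again, so a move of similar or somewhat smaller size back toward lower numbers is expected, although the entering group differs from that of compound 1 and no measured step covers it directly. The estimated step is a 3.5-fold lower number from compound 2 to compound 3 (0.54 log units; beyond the scatter) in this assay as a modest gain. Compound 3 is thus expected at 12000 nM with 4000 nM to 35000 nM as the estimated range.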

Compound 3, concentration for 50% growth inhibition: 10600 nM
Compound 3: middle estimate off by 1.1-fold (0.05 log units), on the high side, within the range that was stated.
By their numbers in this assay, from the lowest: compounds 1 and 3 (each within the scatter of the next); then compound 2.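

In this assay the change to 4-(trifluoromethyl)phenyl on a carbonyl carbon gives a 3.9-fold lower number from compound 2 to compound 3 (0.59 log units; beyond the scatter) and so undoes most of what the 3-cyanophenyl had cost. Trifluoromethyl in place of chloro on an aromatic carbon gives a 1.2-fold higher number from compound 1 to compound 3 (0.08 log units; within the scatter), which leaves compound 1 and compound 3 indistinguishable here and makes compound 2 the only one of the three that stands apart. No measurement at hand offers a reason for these differences.

The compounds shown leave open whether the higher number of compound 2 goes with the nitrile itself or with its place on the phenyl ring, as each substituent appears at one place only. They also leave open how an amine, a carboxylic acid or a methoxy group on that ring would read in this assay.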